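The compounds below may be only part of what the source reports. "The series", "measured", "known", "first", "only" and "open" are said of these compounds alone.

In a functional assay on NCI-H630 cells (Homo sapiens) for cytotoxicity, read by sulforhodamine B assay, with a stated time of 5 days (on this read-out lower numbers stand for stronger inhibition and higher numbers for weaker inhibition), compound 1 `O=C(CCCCCCc1ccccc1)CC(=O)N[C@H]1CCOC1=O` gives 27000 nM and compound 3 `O=C(CCCCCCCc1ccccc1)CC(=O)N[C@H]1CCOC1=O` gives 10000 nM as a measured number. Compound 2 `O=C(CCCCCCCCCc1ccccc1)CC(=O)N[C@@H]1CCOC1=O` gives > 100000 nM as a limit of the assay and not as a number. Compound 3 therefore holds the lower of the two actual numbers. Compound 4 `O=C(CCCCCCCCCc1ccccc1)CC(=O)N[C@H]1CCOC1=O` differs from compound 3 by phenethyl in place of phenyl on a saturated chain carbon, seven bonds along the chain from a carbonyl carbon in one place: phenethyl in place of phenyl on a saturated chain carbon, seven bonds along the chain from a carbonyl carbon. The closest measured change is a 2.7-fold lower number from compound 1 to compound 3 (0.43 log units; beyond the scatter) for benzyl in place of phenyl on a saturated chain carbon, a modest step. On the strength of that step, a small further lowering is expected in this assay of a size near the usual scatter. The limit of compound 2 at > 100000 nM keeps a much weaker outcome open in this expectation. The estimated change is a 2.0-fold lower number from compound 3 to compound 4 (0.30 log units; within the scatter) at the middle of the range. Compound 4 is expected at 5000 nM with an estimated range from 1200 nM to 30000 nM in this assay.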

Compound 4, half-maximal inhibitory concentration: 13000 nM
For compound 4 the middle estimate is 2.6-fold (0.41 log units) below the measured one; measured number inside the range.
By their numbers in this assay, from the lowest: compounds 3 and 4 (each within the scatter of the next); then compound 1. At a limit, above all of these: compound 2.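

In this assay, phenethyl in place of phenyl gives a 1.3-fold higher number from compound 3 to compound 4 (0.11 log units; within the scatter) and so does not carry on the lowering seen earlier along the chain, while 3-phenylpropyl in place of phenyl gives a 2.1-fold lower number from compound 1 to compound 4 (0.32 log units; beyond the scatter) and keeps the benefit over the shorter chain. The result also adds a comparison of configuration at the saturated ring carbon, drawn R in compound 2 and S in compound 4, which gives an at least 7.6-fold lower number from compound 2 to compound 4 (0.88 log units; beyond the scatter) and isolates that stereocentre: the fact that compounds 2 and 4 differ only in the configuration as drawn. That step rests on a limit and not on a number for compound 2: the limit of > 100000 nM in this assay, at which 1 of the 4 values shown sits.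

From the compounds shown here alone, it remains open whether the stereocentre matters as much with the chains of compound 1 and compound 3. Also open, going by these compounds, is how this assay would read for a longer chain, or for a carboxylic acid or an amine at the chain end in place of phenyl.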